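The compounds below may be only part of what the source reports. "The series", "measured", "known", "first", "only" and "open" are said of these compounds alone.

In an assay on isolated protein for inhibition of protein deacetylase HDAC6 (Homo sapiens), read by fluorescence, with a stated time of 15 min (on this read-out lower numbers stand for stronger inhibition and higher numbers for weaker inhibition), the three measured compounds are:
compound 1 `O=C(NO)c1cccc(/C=C/c2ccnc(-c3cc(F)ccc3O)c2)c1`, 400 nM;
compound 2 `O=C(NO)c1ccc(/C=C/c2ccnc(-c3ccccc3O)c2)cc1`, 47 nM;
compound 3 `COc1ccccc1-c1cc(/C=C/c2ccc(C(=O)NO)cc2)ccn1`, 28 nM.

Compound 2 stands second highest of these three numbers; its nearest neighbour is compound 3 (a 1.7-fold lower number from compound 2 to compound 3 (0.22 log units; within the scatter)), and its furthest is compound 1, whose number is the higher of the two. Compound 4 `O=C(NO)c1ccc(/C=C/c2ccncc2)cc1` differs from compound 2 by hydrogen in place of 2-hydroxyphenyl on an aromatic carbon. For the measured compounds named here, no measured step removes this group. Going by the values given here, the only recorded step, a 1.7-fold lower number from compound 2 to compound 3 (0.22 log units; within the scatter), changes just the oxygen on that ring and lies within the scatter, so it gives little guidance on taking the whole ring away. Compound 1 and compound 2 differ in more than one place, so their gap cannot be assigned to a single change. Compound 4 is therefore expected at 200 nM, within 60 nM to 700 nM. That estimated step, a 4.3-fold higher number from compound 2 to compound 4 (0.63 log units; beyond the scatter), is expected to run toward weaker inhibition and beyond the scatter.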

Compound 4, half-maximal inhibitory concentration: 130 nM
Compound 4: the middle estimate sits 1.5-fold (0.19 log units) above what was measured, and the stated range covers the measured number.
By their numbers in this assay, from the lowest: compounds 3 and 2 (each within the scatter of the next); then compound 4; then compound 1.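

Taking the whole ring away from the place next to the ring nitrogen weakens inhibition beyond the scatter, both with hydrogen in place of 2-hydroxyphenyl (a 2.8-fold higher number from compound 2 to compound 4 (0.44 log units; beyond the scatter)) and with hydrogen in place of 2-methoxyphenyl (a 4.6-fold higher number from compound 3 to compound 4 (0.67 log units; beyond the scatter)). The steps are modest, so the ring adds to inhibition at this position with either oxygen group but is not needed for it. Nothing available explains this gain.

From the compounds shown here alone, whether a smaller group such as methyl or an amine at this place would keep the gain remains open. So does the effect of moving the hydroxyl or methoxy group elsewhere on the ring.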